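Replacing 2-fluorophenyl with a larger fluorinated aromatic group

The compounds below may be only part of what the source reports. "The series", "measured", "known", "first", "only" and "open" are said of these compounds alone.

Compound 1 `O=C(NCCCCc1ccccc1)c1cccc(C2SCC(=O)N2c2cccc(-c3c[nH]nn3)c2)c1`: 20000 nM
Compound 2 `O=C(NCCCCc1ccccc1)c1cccc(C2SCC(=O)N2c2ccccn2)c1`: 20000 nM
Compound 3 `O=C(NCCCCc1ccccc1)c1cccc(C2SCC(=O)N2c2ccccc2F)c1`: 10000 nM

In a physicochemical assay for solubility, read by turbidimetry, measured as kinetic solubility, at pH 7.4 (on this read-out higher numbers stand for higher solubility and lower numbers for lower solubility), compound 3 gives 10000 nM, which lies within the scatter of the numbers for the other two compounds. Compound 4 `CC(F)(F)c1cccc(N2C(=O)CSC2c2cccc(C(=O)NCCCCc3ccccc3)c2)c1` differs from it by a group of 10 heavy atoms (8 carbon, 2 fluorine; one six-membered aromatic ring of carbon only) in place of a group of 7 heavy atoms (6 carbon, 1 fluorine; one six-membered aromatic ring of carbon only), on an amide-type nitrogen in a ring. Three measured steps exchange groups at this same place, on an amide-type nitrogen in a ring: a 2.0-fold lower number from compound 1 to compound 3 (0.30 log units; within the scatter), a 2.0-fold lower number from compound 2 to compound 3 (0.30 log units; within the scatter) and no change at the digits printed from compound 1 to compound 2 (within the scatter). All three stay within the scatter, so no step beyond the scatter is expected in this assay. The expected step is a 1.3-fold lower number from compound 3 to compound 4 (0.10 log units; within the scatter). For compound 4 the estimated value is 8000 nM, with an expected range from 3000 nM to 20000 nM.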

Compound 4, solubility: 2000 nM
Compound 4: middle estimate off by 4.0-fold (0.60 log units), on the high side; the whole stated range lies above it.
By their numbers in this assay, from the lowest: compound 4; then compounds 3, 1 and 2 (each within the scatter of the next).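

In this assay, the earlier exchanges on the amide-type nitrogen in a ring all stayed within the scatter, but this one goes beyond it: a 5.0-fold lower number from compound 3 to compound 4 (0.70 log units; beyond the scatter), a 10-fold lower number from compound 2 to compound 4 (1.00 log units; beyond the scatter) and a 10-fold lower number from compound 1 to compound 4 (1.00 log units; beyond the scatter). The group at this position can therefore shift the read-out, and compound 4 stands apart from the other three compounds. No measurement shown gives a cause for this shift.

Going by these compounds, it stays open whether a plain ethyl would give the same step as 1,1-difluoroethyl. On these data alone, it also stays open whether an amine or a carboxylic acid in its place would bring the number back towards that of compound 1.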